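Ester variation on a flavanonol-linked core: step to compound 3

The compounds below may be only part of what the source reports. "The series", "measured", "known", "first", "only" and "open" are said of these compounds alone.

Measured so far:
compound 1 `COc1cc(C2Oc3cc([C@H]4Oc5cc(O)cc(O)c5C(=O)[C@@H]4O)ccc3OC2COC(=O)c2cc(OC)c(OC)c(OC)c2)ccc1O` — 94800 nM
compound 2 `CCOC(=O)CC(=O)OCC1Oc2ccc([C@H]3Oc4cc(O)cc(O)c4C(=O)[C@@H]3O)cc2OC1c1ccc(O)c(OC)c1` — 101000 nM

Both compounds share one core and differ only in the group on the carbonyl carbon of the ester. In a functional assay, read by spectrophotometry, with a stated time of 30 min (on this read-out lower numbers stand for an effect already at smaller amounts and higher numbers for an effect only at larger amounts of compound), compound 1 gives 94800 nM and compound 2 gives 101000 nM. Compound 2 holds the highest number of the two, but the step of a 1.1-fold higher number from compound 1 to compound 2 (0.03 log units; within the scatter) is within the scatter, so the two values cannot be ordered.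

Compound 3 `COc1cc(C2Oc3cc([C@H]4Oc5cc(O)cc(O)c5C(=O)[C@@H]4O)ccc3OC2COC(=O)/C=C/c2ccc(Br)cc2)ccc1O` has not yet been measured. It differs from compound 2 as follows: 2-(4-bromophenyl)ethenyl in place of (ethoxycarbonyl)methyl on a carbonyl carbon. Within the data shown here, the one step known so far at this very place, a 1.1-fold higher number from compound 1 to compound 2 (0.03 log units; within the scatter), left the number unchanged within the scatter although a trimethoxyphenyl gave way to an (ethoxycarbonyl)methyl. Among the measured compounds shown here, no step involving an alkenyl or a bromophenyl group is available, so nothing beyond this single step bears on the change.

On that basis the step from compound 2 to compound 3 is expected to be small, a 1.0-fold lower number from compound 2 to compound 3 (0.00 log units; within the scatter), with no direction beyond the scatter. Compound 3 is therefore estimated at 100000 nM, with a range from 40000 nM to 250000 nM.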

Compound 3, half-maximal effective concentration: 88900 nM
Compound 3: middle estimate off by 1.1-fold (0.05 log units), on the high side, and the stated range covers the measured number.
By their numbers in this assay, from the lowest: compounds 3, 1 and 2 (each within the scatter of the next).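

In this assay, the 2-(4-bromophenyl)ethenyl group on the carbonyl carbon gives a 1.1-fold lower number from compound 2 to compound 3 (0.06 log units; within the scatter) and a 1.1-fold lower number from compound 1 to compound 3 (0.03 log units; within the scatter), so a group with a bromine-bearing six-membered aromatic ring and a double bond outside it joins (ethoxycarbonyl)methyl and 3,4,5-trimethoxyphenyl without a readable shift. Across compounds 1, 2 and 3, this place therefore accepts an open ester-bearing chain, an aromatic ring bound directly to the carbonyl carbon and an aromatic ring reached through a double bond, with all three values within the scatter of one another. No measurement at hand speaks to why the number holds across such different groups.

From the compounds shown here alone, whether an amine, a carboxylic acid or a simple longer alkyl chain on the same carbonyl carbon would move the number beyond the scatter remains open. Going by these compounds, all three compounds carry the shared core unchanged, so it is also open whether the number would respond to a change elsewhere on the core, or whether the ester group would matter more with such a change in place.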